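The compounds below may be only part of what the source reports. "The series", "measured", "known", "first", "only" and "open" are said of these compounds alone.

Series notes. Compound 1 `CCCC(=O)Nc1ccc(S(=O)(=O)Oc2ccccc2I)cc1` gives 11000 nM in a functional assay on HT-29 cells (Homo sapiens) for antiproliferative activity, read by sulforhodamine B assay, with a stated time of 48 h; a lower number here means a stronger inhibitor, a higher number a weaker inhibitor. Going by the values given here, compound 2 `O=C(CCl)Nc1ccc(S(=O)(=O)Oc2ccccc2I)cc1` gives 4100 nM in this assay; the step of a 2.7-fold lower number from compound 1 to compound 2 (0.43 log units; beyond the scatter) is the only measured single change. Compound 3 `CC(C)c1ccccc1OS(=O)(=O)c1ccc(NC(=O)CCCCl)cc1` gives 6200 nM in this assay, which stands second highest of the three numbers, within the scatter of both compound 2 and compound 1. Compound 4 `O=C(CCCCl)Nc1ccc(S(=O)(=O)Oc2ccccc2I)cc1` differs from compound 3 by iodo in place of isopropyl on an aromatic carbon. Among the compounds with values here, no measured step touches that aromatic carbon; the single measured step alters the amide chain instead and does not bear on this change. The expectation is therefore no step beyond the scatter. Compound 4 is expected at 6000 nM in this assay, between 2500 nM and 14000 nM. The expected step is a 1.0-fold lower number from compound 3 to compound 4 (0.01 log units; within the scatter).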

Compound 4, half-maximal inhibitory concentration: 9100 nM
For compound 4 the middle estimate is 1.5-fold (0.18 log units) below the measured one, and the stated range covers the measured number.
By their numbers in this assay, from the lowest: compounds 2, 3, 4 and 1 (each within the scatter of the next, the first and the last beyond it).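

Iodo in place of isopropyl on the aromatic carbon gives a 1.5-fold higher number from compound 3 to compound 4 (0.17 log units; within the scatter) in this assay and so does not separate the two groups at this position. With 2-chloroethyl in place of chloro the step is a 2.2-fold higher number from compound 2 to compound 4 (0.35 log units; beyond the scatter) and with chloro in place of hydrogen on the chain it is a 1.2-fold lower number from compound 1 to compound 4 (0.08 log units; within the scatter), so chloro on the longer chain does not reproduce the lower number of compound 2. Nothing available here accounts for these steps.

Open, on these data alone, is whether an amine or a carboxylic acid on the amide chain would shift the number. Also open, as far as these compounds go, is whether iodo and isopropyl stay level on the shorter chain of compound 2.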